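A Fluoro Swap on a Weakly Active Pair

The source may hold more compounds than are shown below. What is called first, only, known or untested is meant among the compounds shown, and "the series" means these compounds.

In a functional assay on MDA-MB-231 cells (Homo sapiens) for antiproliferative activity, read by MTT assay, with a stated time of 72 h (on this read-out higher numbers stand for weaker inhibition and lower numbers for stronger inhibition), compound 1 (`CC1=CC[C@H]2[C@H](CC[C@]2(C)O)C(C)(C)[C@@H]1CC[C@H]1[C@]2(C)CC[C@H](OC(=O)c3ccc(C)cc3)C(C)(C)O[C@H]2CC[C@@]1(C)O`) gives 33400 nM and compound 2 (`CC1=CC[C@H]2[C@@H]1CC=C(C)[C@@H](CC[C@H]1[C@]3(C)CC[C@H](OC(=O)c4ccc(C)cc4)C(C)(C)O[C@H]3CC[C@@]1(C)O)C2(C)C`) gives 32700 nM. These two numbers lie within the usual scatter of each other, so compound 1 shares its place with compound 2 and neither can be ranked ahead. Compound 3 (`CC1=CC[C@H]2[C@H](CC[C@]2(C)O)C(C)(C)[C@@H]1CC[C@H]1[C@]2(C)CC[C@H](OC(=O)c3ccc(F)cc3)C(C)(C)O[C@H]2CC[C@@]1(C)O`) departs from compound 1 by one change: fluoro in place of methyl on an aromatic carbon. Going by the values given here, no two measured compounds differ in one place only, so the data offer no direct guide to this change. In this assay, no shift beyond the scatter is expected, and the estimate stays anchored on compound 1 at 33400 nM. The expected change is a 1.1-fold lower number from compound 1 to compound 3 (0.05 log units; within the scatter). Compound 3 is estimated at 30000 nM, with an expected range from 14000 nM to 60000 nM.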

Compound 3, half-maximal inhibitory concentration: 11300 nM
Compound 3: the middle estimate sits 2.7-fold (0.42 log units) above what was measured; the measured number lies below the stated range.
By their numbers in this assay, from the lowest: compound 3; then compounds 2 and 1 (each within the scatter of the next).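

In this assay, going by these compounds alone, replacing 4-methylphenyl with 4-fluorophenyl gives a 3.0-fold lower number from compound 1 to compound 3 (0.47 log units; beyond the scatter), the first single change in this set to be read directly. It shows that this aromatic carbon, para to a large group, is not indifferent to substitution: an exchange of one heavy atom for another, with no hydrogen-bond donor or acceptor and no net charge on either side, moves the number beyond the scatter. No measurement at hand explains this shift.

As far as these compounds go, it remains open whether the gain depends on fluoro specifically or on the loss of methyl, and how chloro, methoxy or an amine would read on the same carbon. Also unresolved is whether the same exchange would shift the number for compound 2, whose core differs from that of compound 1.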